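From Amino to Dimethylamino: One Step in a Cytotoxicity Series

The source may report more compounds than this note shows. Statements on the series, on what has been measured and on what is new or still open speak of the compounds shown alone.

Of the compounds shown here, two with a shared core have been tested in a functional assay on HeLa cells (Homo sapiens) for cytotoxicity, read by neutral red uptake, with a stated time of 3 days; a lower number here means a stronger inhibitor, a higher number a weaker inhibitor. Compound 1, `CCc1c(F)c(N)c2c(=O)cc(-c3ccc(N)c(F)c3)oc2c1F`, carries a methyl group on a saturated chain carbon bound to an aromatic carbon. In this assay compound 1 reaches only a limit of the measurement, > 100000 nM. Compound 2, `NCc1c(F)c(N)c2c(=O)cc(-c3ccc(N)c(F)c3)oc2c1F`, has an amino group in place of that methyl. In this assay, among the compounds with values here, compound 2 gives 8800 nM, the only actual number in the set. The other entry sits at the limit of > 100000 nM in this assay, at which 1 of the 2 values shown sits. Within the data shown here, the measured change between them, an at least 11-fold lower number from compound 1 to compound 2 (1.05 log units; beyond the scatter), is the one step that bears on the question below.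

Compound 3, `CN(C)Cc1c(F)c(N)c2c(=O)cc(-c3ccc(N)c(F)c3)oc2c1F`, differs from compound 2 in one place: dimethylamino in place of amino on a saturated chain carbon bound to an aromatic carbon. The earlier step shows that a nitrogen on this chain carbon goes with a much lower number, but nothing measured tells what happens when that nitrogen carries two methyl groups instead of hydrogens. Since the nitrogen remains, no step beyond the scatter is expected, with a mild lean toward a higher number. Compound 3 is therefore estimated at 12000 nM, within 4000 nM to 40000 nM, an expected step of a 1.4-fold higher number from compound 2 to compound 3 (0.13 log units; within the scatter).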

Compound 3, half-maximal inhibitory concentration: 8900 nM
The estimate for compound 3 lay 1.3-fold (0.13 log units) above the measured number; low and high end bracket the measured number.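

In this assay, dimethylamino in place of amino on this saturated chain carbon leaves the number within the scatter, a 1.0-fold higher number from compound 2 to compound 3 (0.00 log units; within the scatter), even though the dimethylamino group brings more heavy atoms and no hydrogen-bond donor. Within this pair, then, the hydrogens on the nitrogen can give way to two methyl groups without a measurable difference, and the low number seen with amino is not tied to those hydrogens. Against the methyl-bearing compound, the dimethylamino group also gives a large step, an at least 11-fold lower number from compound 1 to compound 3 (1.05 log units; beyond the scatter), but compound 1 marks a limit of the assay and not a number, so that step has no upper end: the limit of > 100000 nM in this assay, at which 1 of the 3 values shown sits.

On these data alone, what remains open is whether nitrogen itself is what sets compounds 2 and 3 apart from compound 1, a question that a hydroxyl group on the same chain carbon could help to answer. Also open, as far as these compounds go, is how much more the nitrogen can carry, as a diethylamino group or a morpholine ring would show, and whether a longer chain between the aromatic carbon and the nitrogen gives a similar number.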